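A few compounds are considered here, and "the series" means these few. Any claim that something is new, unique, unknown or untested is made for them only; others in the source may bear on it.

Compound 1 `COc1ccccc1OCC1SCCN1C(=O)CSC` gives 21 mg/kg
Compound 2 `COc1ccccc1OCC1SCCN1C(=O)CNc1cc(Br)cc(Br)c1O` gives 20 mg/kg
Compound 3 `COc1ccccc1OCC1SCCN1C(=O)COC(C)=O` gives 25 mg/kg

In a functional assay on the whole organism (trachea) for inhibition, with Cavia porcellus as the target (a higher number here means that more compound is needed for the effect, a lower number that less compound is needed), compound 3 stands within the scatter of both compound 1 and compound 2, so the three cannot be ranked. Compound 4 `COc1ccccc1OCC1SCCN1C(=O)CC(C)=O` carries acetyl in place of acetoxy on a saturated chain carbon bound to a carbonyl carbon. For the measured compounds named here, no measured step makes this exact swap. The nearest is a 1.2-fold higher number from compound 1 to compound 3 (0.08 log units; within the scatter) at that same place, and it stays within the scatter. Compound 2 carries another group there and, at 20 mg/kg in the same test, also sits within the scatter of compound 3. No step beyond the scatter is therefore expected. The estimated step is a 1.1-fold lower number from compound 3 to compound 4 (0.06 log units; within the scatter) in this assay and lies within the scatter. Compound 4 is expected at 22 mg/kg (estimated range 12 mg/kg to 40 mg/kg).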

Compound 4, dose for half-maximal effect: 26 mg/kg
For compound 4 the middle estimate is 1.2-fold (0.07 log units) below the measured one, and the stated range covers the measured number.
By their numbers in this assay, from the lowest: compounds 2, 1, 3 and 4 (each within the scatter of the next).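

In this assay, acetyl in place of acetoxy on a saturated chain carbon bound to a carbonyl carbon gives a 1.0-fold higher number from compound 3 to compound 4 (0.02 log units; within the scatter), and acetyl in place of methylsulfanyl gives a 1.2-fold higher number from compound 1 to compound 4 (0.09 log units; within the scatter). So a group with one oxygen, instead of the two in acetoxy, leaves the number within the scatter, and this place has now tolerated a ketone as well. No measurement here explains this insensitivity. Still open, as far as these compounds go, is whether a carboxylic acid or a simple amine at this place would move the number beyond the scatter.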